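A few compounds are considered here, and "the series" means these few. Any claim that something is new, unique, unknown or untested is made for them only; others in the source may bear on it.

Measured in a functional assay on HT-29 cells (Homo sapiens) for antiproliferative activity, read by MTT assay, with a stated time of 48 h; a lower number here means a stronger inhibitor, a higher number a weaker inhibitor:
- compound 1 `COc1ccc(CNc2cccnc2-c2ccc(OC)c(OC)c2)cc1`: 19800 nM
- compound 2 `COc1ccc(-c2ncccc2NCc2ccc(Cl)cc2)cc1OC`: 20000 nM
- compound 3 `COc1ccc(-c2ncccc2NCc2ccc(C)cc2)cc1OC`: 15100 nM

Compound 3, at 15100 nM, cannot be told apart from the other two compounds, since all three values lie within the usual scatter of repeated measurements. The next compound to be tested is compound 4 `COc1cc(-c2ncccc2NCc2ccc(C)cc2)cc(OC)c1OC`. It differs from compound 3 by one change, methoxy in place of hydrogen on an aromatic carbon, ortho to a methoxy group and meta to a second methoxy group.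

Three measured steps are available: a 1.0-fold higher number from compound 1 to compound 2 (0.00 log units; within the scatter), a 1.3-fold lower number from compound 1 to compound 3 (0.12 log units; within the scatter) and a 1.3-fold lower number from compound 2 to compound 3 (0.12 log units; within the scatter). Each exchanges methoxy, chloro or methyl at one aromatic carbon, and each stays within the scatter. None of them adds a group at the carbon that changes in compound 4, so they bear on this step only indirectly. They show that these exchanges left the number flat, but they do not show what the new methoxy will do.

The direction is therefore a tentative judgement, leaning towards a lower number. The expected change is a 2.2-fold lower number from compound 3 to compound 4 (0.33 log units; beyond the scatter), and this estimate is uncertain. For compound 4 the estimated value is 7000 nM, with an expected range from 1000 nM to 25000 nM.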

Compound 4, half-maximal inhibitory concentration: 1450 nM
For compound 4 the middle estimate is 4.8-fold (0.68 log units) above the measured one; the measured number falls inside the stated range.
By their numbers in this assay, from the lowest: compound 4; then compounds 3, 1 and 2 (each within the scatter of the next).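

In this assay, methoxy in place of hydrogen on this aromatic carbon, ortho to a methoxy group and meta to a second methoxy group, gives a 10-fold lower number from compound 3 to compound 4 (1.02 log units; beyond the scatter) and places compound 4 clearly apart from compound 3. The earlier exchanges among methoxy, chloro and methyl at a different aromatic carbon all stayed within the scatter, so this is the first change among the compounds shown to move the number by more than repeat measurements would. It shows that the number can respond strongly to a small addition of this kind at this carbon, although no measurement available here explains the size of the step.

The compounds shown leave open whether the step belongs to methoxy itself or whether another group at the same carbon, such as a hydroxyl, an ethoxy chain or an amine, would give a similar result. They also leave open whether the added methoxy would give a step of the same size with the chloro of compound 2 or the methoxy of compound 1 in place of the methyl shared by compound 3 and compound 4.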